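A few compounds are considered here, and "the series" means these few. Any claim that something is new, unique, unknown or untested is made for them only; others in the source may bear on it.

Compound 1 `CCCCCCCCCCCC(=O)OC[C@H](CSC[C@@H](N)C(=O)N[C@H](C)CO)OC(=O)CCCCCCCCCCC` gives 22200 nM in an assay on HEK293 cells for agonist activity at Toll-like receptor 2 (Homo sapiens); a higher number here means that more compound is needed for the effect, a lower number that less compound is needed.
Compound 2 `CCCCCCCCCCCC(=O)OC[C@H](CSC[C@@H](N)C(=O)NCCCCCCO)OC(=O)CCCCCCCCCCC` gives 33 nM in this assay.
Compound 3 `CCCCCCCCCCCC(=O)OC[C@H](CSC[C@@H](N)C(=O)NCCCC(C)(C)CO)OC(=O)CCCCCCCCCCC` gives 30700 nM in this assay.

Compound 2 has the lowest number of the three: a 670-fold lower number from compound 1 to compound 2 (2.83 log units; beyond the scatter) and a 930-fold higher number from compound 2 to compound 3 (2.97 log units; beyond the scatter) are both far beyond the scatter, while compound 1 and compound 3 lie within the scatter of each other. Compound 4 `CCCCCCCCCCCC(=O)OC[C@H](CSC[C@@H](N)C(=O)NCCCCCC(=O)O)OC(=O)CCCCCCCCCCC` differs from compound 2 in one place: carboxy in place of hydroxymethyl on a saturated chain carbon, five bonds along the chain from an amide-type nitrogen. Among the compounds with values here, no measured step exchanges hydroxymethyl for carboxy; the two large steps show only that the group on the amide nitrogen governs the number, so a change at its far end may still matter. A modest rise in this assay is expected, a 6.1-fold higher number from compound 2 to compound 4 (0.78 log units; beyond the scatter). Compound 4 is therefore estimated at 200 nM, between 30 nM and 3000 nM.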

Compound 4, half-maximal effective concentration: 108 nM
Estimate against measurement, compound 4: 1.9-fold (0.27 log units) above; the range from low to high includes it.
By their numbers in this assay, from the lowest: compound 2; then compound 4; then compounds 1 and 3 (each within the scatter of the next).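

Exchanging hydroxymethyl for carboxy at this place, five bonds along the chain from the amide-type nitrogen, is only a modest change in this assay (a 3.3-fold higher number from compound 2 to compound 4 (0.51 log units; beyond the scatter)). So hydroxymethyl is not the only end group that gives a low number on this chain, and the large steps remain (a 210-fold lower number from compound 1 to compound 4 (2.31 log units; beyond the scatter); a 280-fold lower number from compound 3 to compound 4 (2.45 log units; beyond the scatter)). Nothing available explains why the exchange costs so little.

From the compounds shown here alone, whether an amine or a primary amide at this chain end would behave the same stays open, as does whether a longer chain carrying carboxy would.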